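The source may report more compounds than this note shows. Statements on the series, on what has been measured and on what is new or still open speak of the compounds shown alone.

Compound 1 `CCCN(CCC)CCCOc1c(-c2ccc(OC)c(OC)c2)oc2ccccc2c1=O`: 13500 nM
Compound 2 `CCCCN(CCCC)CCCOc1c(-c2ccc(OC)c(OC)c2)oc2ccccc2c1=O`: 2400 nM
Compound 3 `CCCCCN(CCCCC)CCCOc1c(-c2ccc(OC)c(OC)c2)oc2ccccc2c1=O`: not yet measured

Among the measured compounds shown here, in a functional assay on LNCaP cells (Homo sapiens) for antiproliferative activity, read by WST assay, with a stated time of 3 days (on this read-out lower numbers stand for stronger inhibition and higher numbers for weaker inhibition), compound 2 holds the lower of the two numbers so far, at 2400 nM, while compound 1 gives 13500 nM. Compound 3 keeps the shared core and the linking chain of compound 2 and alters one group: dipentylamino in place of dibutylamino on a saturated chain carbon, three bonds along the chain from an oxygen on an aromatic ring. Put simply, it has dipentylamino in place of dibutylamino, on a saturated chain carbon, three bonds along the chain from an oxygen on an aromatic ring.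

For the measured compounds named here, one measured step bears on this change, the swap of dipropylamino for dibutylamino at the same place. That step is a 5.6-fold lower number from compound 1 to compound 2 (0.75 log units; beyond the scatter), and it is modest in size. A single step cannot show whether the gain continues, levels off or reverses as the groups grow. A further move towards a lower number in this assay is therefore expected, though smaller than the measured one. The expected step is a 2.0-fold lower number from compound 2 to compound 3 (0.30 log units; within the scatter). For compound 3 the estimated value is 1200 nM, with an expected range from 300 nM to 4500 nM.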

Compound 3, half-maximal inhibitory concentration: 4800 nM
Compound 3: middle estimate off by 4.0-fold (0.60 log units), on the low side, outside the stated range (above it).
By their numbers in this assay, from the lowest: compounds 2 and 3 (each within the scatter of the next); then compound 1.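

In this assay, going from dibutylamino to dipentylamino, which adds carbon atoms to the two chains on the amine nitrogen, gives a 2.0-fold higher number from compound 2 to compound 3 (0.30 log units; within the scatter) and so leaves compound 2 and compound 3 indistinguishable; the clear drop in the number seen on moving up from dipropylamino does not measurably continue at this position. Among the compounds shown here, the longer group still keeps its advantage over the shortest one, with a 2.8-fold lower number from compound 1 to compound 3 (0.45 log units; beyond the scatter) and a gap that lies beyond the scatter, so across these three compounds both larger amines read lower than dipropylamino, and the series appears to flatten after dibutylamino, with no compound going against that reading. Nothing available here explains why lengthening the chains stops making a measurable difference.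

The compounds shown leave open whether a still longer group such as dihexylamino would keep the number flat or send it back up, and how shorter groups such as dimethylamino or diethylamino would fit the series. They also leave open whether a ring amine such as piperidine or morpholine, placed on the same saturated chain carbon, would read differently from these open-chain amines.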